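This account rests on a few compounds, and the source may have more. Where it says the series, first, only, none or still open, it means among the compounds named here.

Compound 1 `CCCCOc1ccc2c(Cl)ccnc2c1` gives 2640 nM in a functional assay on HepG2 cells (Homo sapiens) for cytotoxicity, read by MTT assay, with a stated time of 48 h; a lower number here means a stronger inhibitor, a higher number a weaker inhibitor.
Compound 2 `CCOc1ccc2c(Cl)ccnc2c1` gives 2660 nM in this assay.
Compound 3 `C=CCOc1ccc2c(Cl)ccnc2c1` gives 2770 nM in this assay.

These three compounds share one core and differ only in the chain attached to the oxygen on the aromatic ring. Compound 3 has the highest of the three numbers, yet the gaps to its neighbours are small: a 1.0-fold higher number from compound 2 to compound 3 (0.02 log units; within the scatter) and a 1.0-fold higher number from compound 1 to compound 3 (0.02 log units; within the scatter) both stay within the scatter, so no order among the three can be read from them. Likewise a 1.0-fold higher number from compound 1 to compound 2 (0.00 log units; within the scatter) shows that shortening the chain changed nothing that the assay could resolve.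

Compound 4 `CC(C)Oc1ccc2c(Cl)ccnc2c1` is the next member of this set. The change from compound 3 is isopropyl in place of allyl on an oxygen on an aromatic ring, a branched saturated chain in place of one carrying a double bond. All three measured steps bear on this, since each swaps one small chain on that oxygen for another, and each was flat. The step of a 1.0-fold lower number from compound 3 to compound 4 (0.01 log units; within the scatter) is therefore expected to be none beyond the scatter. For compound 4 the estimated value in this assay is 2700 nM, expected to fall between 1350 nM and 5400 nM.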

Compound 4, half-maximal inhibitory concentration: 2050 nM
Compound 4: middle estimate off by 1.3-fold (0.12 log units), on the high side; low and high end bracket the measured number.
By their numbers in this assay, from the lowest: compounds 4, 1, 2 and 3 (each within the scatter of the next).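

Going by these compounds alone, compound 4 brings a branched chain to this oxygen, with isopropyl where the earlier compounds carry unbranched chains, and in this assay the branch gives no shift that can be told from the scatter: a 1.4-fold lower number from compound 3 to compound 4 (0.13 log units; within the scatter), a 1.3-fold lower number from compound 2 to compound 4 (0.11 log units; within the scatter) and a 1.3-fold lower number from compound 1 to compound 4 (0.11 log units; within the scatter). The flat picture from the first three compounds, which covered chains of different lengths and one with a double bond, therefore now extends to a branched chain, and all four compounds remain within the scatter of one another. The data shown give no reason why these swaps on the oxygen leave the number so unmoved.

Going by these compounds, all four groups on this oxygen are plain hydrocarbon chains, so it remains open what a much longer chain such as octyl, a benzyl group, or a chain ending in an amine or a carboxylic acid would do in this assay. Every compound shown also keeps the chlorine on the shared core, which leaves open whether an amine in its place would move the number beyond the scatter.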